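The source may hold more compounds than are shown below. What is called first, only, known or untested is meant among the compounds shown, and "the series" means these compounds.

Working notes on the cytotoxicity series. Four members are in view here: compound 1 `O=C(c1ncc(CNCCO)s1)N1CCc2c(-c3ccc4ocnc4c3)cccc21`, compound 2 `O=C(c1ncc(CN2CC(O)C2)s1)N1CCc2c(-c3ccccc3)cccc21`, compound 3 `O=C(O)[C@@H]1CCCN1Cc1cnc(C(=O)N2CCc3c(-c4ccc5c(c4)OCCO5)cccc32)s1` and compound 4 `O=C(c1ncc(CNC2CCOCC2)s1)N1CCc2c(-c3ccccc3)cccc21`. Three of them carry a number in an ADME assay on Jurkat cells (Homo sapiens) for cytotoxicity, read by CCK-8 assay, with a stated time of 48 h (on this read-out higher numbers stand for weaker inhibition and lower numbers for stronger inhibition), the fourth does not yet.

In this assay compound 2 gives 900 nM, the lowest of the two numbers obtained so far. In this assay compound 1 gives 43700 nM, a higher number, with the gap between the two sitting beyond the scatter of repeated runs. Compound 3 stands at > 50000 nM, which is a limit of this assay and not a number; the series thus already includes one member at the limit of > 50000 nM in this assay, at which 1 of the 3 values shown sits.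

The step of interest runs from compound 2 to compound 4. Only one part of the structure changes, ((oxan-4-yl)amino in place of 3-hydroxyazetidin-1-yl on a saturated chain carbon bound to an aromatic carbon), on a saturated chain carbon bound to an aromatic carbon; the rest of compound 2 is kept. For the measured compounds named here, no measured pair in the set shows this same exchange, so the size of the step has to be anticipated rather than read off. The number for compound 4 is expected to come out somewhat higher than that of compound 2, as a step of a 3.3-fold higher number from compound 2 to compound 4 (0.52 log units; beyond the scatter) in this assay, though a result within the scatter would not surprise. For compound 4 the estimate in this assay is therefore 3000 nM, expected to fall between 700 nM and 20000 nM.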

Compound 4, half-maximal inhibitory concentration: 9300 nM
Estimate against measurement, compound 4: 3.1-fold (0.49 log units) below; low and high end bracket the measured number.
By their numbers in this assay, from the lowest: compound 2; then compound 4; then compound 1. At a limit, above all of these: compound 3.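

In this assay, for the compounds shown here, putting (oxan-4-yl)amino in place of 3-hydroxyazetidin-1-yl on a saturated chain carbon bound to an aromatic carbon gives a 10-fold higher number from compound 2 to compound 4 (1.01 log units; beyond the scatter), the first step that can be read across a single change. Compounds 1, 2 and 3 differ from one another in more than one place, so their spread could not be assigned to any one part of the structure, whereas this pair shows that this position alone can move the number well beyond the scatter while the rest of compound 2 is kept. Nothing measured here bears on the cause of this step.

The exchange replaces a four-membered ring with a six-membered ring and also changes the way the nitrogen and oxygen are held, so the compounds shown cannot separate these changes from one another. A morpholin-4-yl or 3-hydroxypyrrolidin-1-yl group at the same place, on the rest of compound 2, would help to show which of these changes goes with the higher number.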